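A few compounds are considered here, and "the series" means these few. Any claim that something is new, unique, unknown or untested is made for them only; others in the source may bear on it.

Of the compounds shown here, two have been measured in a functional assay on A549 cells (Homo sapiens) for cytotoxicity, read by MTT assay, with a stated time of 72 h; on this read-out higher numbers stand for weaker inhibition and lower numbers for stronger inhibition. Compound 1 `Cn1c(=O)c(C(=O)Nc2ccc(Oc3ccncc3-c3cccnc3)c(F)c2)nn(-c2ccccc2F)c1=O` gives 610 nM. Compound 2 `O=C(Nc1ccc(Oc2ccncc2-c2cccnc2)c(F)c1)c1nn(-c2cccc(F)c2)c(=O)c2ccccc12` gives 1750 nM, the higher of the two numbers, so compound 2 inhibits the cells less strongly than compound 1, and this gap lies beyond the usual scatter of repeated measurements. Compound 3 `O=C(Nc1ccc(Oc2ccncc2-c2cccnc2)c(F)c1)c1nn(-c2ccc(F)cc2)c(=O)c2ccccc12` has not yet been measured. It differs from compound 2 in one place: 4-fluorophenyl in place of 3-fluorophenyl on an aromatic nitrogen. Among the measured compounds shown here, no measured pair shows what such an exchange does in this assay, so no step size can be read from the numbers themselves. For compound 3 the expected step in this assay is a 1.2-fold lower number from compound 2 to compound 3 (0.07 log units; within the scatter), small enough to remain within the usual scatter in either direction. Compound 3 is therefore estimated to give about 1500 nM in this assay, with a likely range from 600 nM to 3800 nM.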

Compound 3, half-maximal inhibitory concentration: 820 nM
Estimate against measurement, compound 3: 1.8-fold (0.26 log units) above; measured number inside the range.
By their numbers in this assay, from the lowest: compounds 1 and 3 (each within the scatter of the next); then compound 2.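

In this assay, among the compounds shown here, exchanging 3-fluorophenyl for 4-fluorophenyl on the aromatic nitrogen gives a 2.1-fold lower number from compound 2 to compound 3 (0.33 log units; beyond the scatter), the first step that can be read from a single change. The two groups have the same atoms, joined differently, so this modest step shows that the read-out responds to where the fluorine sits on this group, and not only to whether it is there. Nothing at hand explains why the change has this effect.

The steps from compound 1 to compound 2 and to compound 3 cannot be read, as compound 1 differs from both in more than one place. Also open, going by these compounds, is how this position would respond to an unsubstituted phenyl, a 4-chlorophenyl or a 4-methoxyphenyl group, so the result cannot yet be extended into a trend.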